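Meta-aryl substituent changes on the trimethoxyphenyl benzimidazole core

The compounds below may be only part of what the source reports. "The series", "measured", "known", "first", "only" and "open" are said of these compounds alone.

Measured so far:
- compound 1 `COc1cc(-n2cnc3ccc(-c4cccc(Cl)c4)cc32)cc(OC)c1OC`: 3120 nM
- compound 2 `COc1cc(-n2cnc3ccc(-c4cccc(C)c4)cc32)cc(OC)c1OC`: 360 nM

In a functional assay on MCF7 cells (Homo sapiens) for antiproliferative activity, read by MTT assay, with a stated time of 72 h (on this read-out lower numbers stand for stronger inhibition and higher numbers for weaker inhibition), compound 2 holds the lowest of the two numbers measured; its nearest neighbour is compound 1, which differs only in a chloro in place of the methyl on the aromatic carbon, and the step of an 8.7-fold lower number from compound 1 to compound 2 (0.94 log units; beyond the scatter) shows the methyl-bearing compound 2 well beyond the scatter from compound 1.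

Compound 3 `COc1cccc(-c2ccc3ncn(-c4cc(OC)c(OC)c(OC)c4)c3c2)c1` is not yet measured. It differs from compound 2 by methoxy in place of methyl on an aromatic carbon.

Going by the values given here, the only step that bears on this position, an 8.7-fold lower number from compound 1 to compound 2 (0.94 log units; beyond the scatter), shows that a one-atom change on this aromatic carbon can move the number far. Methoxy has no measured precedent here, so the direction is uncertain; a modest weakening from compound 2 is expected, a 1.7-fold higher number from compound 2 to compound 3 (0.22 log units; within the scatter), with the range left wide. Compound 3 is thus estimated at 600 nM, between 150 nM and 2500 nM.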

Compound 3, half-maximal inhibitory concentration: 1610 nM
Compound 3: middle estimate off by 2.7-fold (0.43 log units), on the low side; the measured number falls inside the stated range.
By their numbers in this assay, from the lowest: compound 2; then compounds 3 and 1 (each within the scatter of the next).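

In this assay, the step of a 4.5-fold higher number from compound 2 to compound 3 (0.65 log units; beyond the scatter) shows that methyl is not simply one of several groups tolerated on this aromatic carbon, as methoxy also gives up much of what methyl gains over chloro. With a 1.9-fold lower number from compound 1 to compound 3 (0.29 log units; within the scatter), methoxy and chloro cannot be told apart here, which leaves the 3-methylphenyl of compound 2 as the only one of these three substituents that stands clear of the others. No measurement in hand explains the difference between methyl and the other two groups.

From the compounds shown here alone, whether the advantage of methyl extends to an ethyl or isopropyl group remains open, as does how an amine or a hydroxyl group would behave on this carbon. The three compounds also do not show whether this ranking holds in other cell lines.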